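Swapping a cyclohexyl for 1-phenylethyl on a histamine receptor agonist

The compounds below may be only part of what the source reports. "The series", "measured", "known", "first", "only" and "open" are said of these compounds alone.

Three compounds share an aminothiazole-bearing core joined to a guanidine that carries a urea-type group. Compound 1, `CCCNC(=O)/N=C(\N)Nc1cccc(-c2csc(N)n2)c1`, has in a functional assay on HEK293T cells for agonist activity at histamine H2 receptor (Homo sapiens), read by beta-arrestin recruitment (on this read-out higher numbers stand for larger maximal responses and lower numbers for smaller maximal responses), only the entry "not determined" (no result reported), so no number is in hand for it. Compound 2, `Cc1nc(N)sc1CCCN/C(N)=N/C(=O)NC1CCCCC1`, reaches 0.43 in this assay, the higher of the two numbers in hand. Compound 3, `N/C(=N\C(=O)NCc1ccccc1)NC1CCc2nc(N)sc2C1`, gives 0.31 in this assay, a gap from compound 2 that is beyond the usual scatter, though the two differ in more than one place, so no single change accounts for it.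

Compound 4, `Cc1nc(N)sc1CCCN/C(N)=N/C(=O)N[C@@H](C)c1ccccc1`, differs from compound 2 only at the amide-type nitrogen: 1-phenylethyl in place of cyclohexyl on an amide-type nitrogen. Within the data shown here, no pair measured so far isolates this kind of change. Among the measured compounds shown here, a modest decrease in this assay is expected, since the only other compound with an aromatic group at that position, compound 3, reaches 0.31. The step from compound 2 to compound 4 is therefore estimated as a number 0.070 lower from compound 2 to compound 4 (within the scatter), a change close to the edge of the scatter. Compound 4 is expected to reach 0.36 in this assay, within a range from 0.2 to 0.55.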

Compound 4, intrinsic activity: the largest response reached, as a fraction of the reference agonist's: 0.46
Beside the measured number, compound 4's estimate is 0.10 below it, and the stated range covers the measured number.
By their numbers in this assay, from the lowest: compound 3; then compounds 2 and 4 (each within the scatter of the next).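

In this assay, replacing cyclohexyl with 1-phenylethyl on the amide-type nitrogen gives a number 0.030 higher from compound 2 to compound 4 (within the scatter) and so leaves the maximal response indistinguishable between the two compounds. Among these compounds, this is the first comparison here that isolates this position, and it shows that a non-aromatic ring of carbon can give way to an aromatic ring, with two more heavy atoms and a defined stereocentre, without a measurable change in this read-out. Nothing available explains why the two groups give such similar responses.

On these data alone, it remains open whether the mirror-image form of 1-phenylethyl would match compound 4. As far as these compounds go, the same position could also carry a benzyl group, a longer chain such as 3-phenylpropyl, or a group bearing an amine or a carboxylic acid, and the response to any of these is unknown.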